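Amide Replacement at the Thiazole-Type Core

The source may report more compounds than this note shows. Statements on the series, on what has been measured and on what is new or still open speak of the compounds shown alone.

Measured compounds:
compound 1, `COc1ccc(-c2nc(CN(C)C)sc2-c2ccc(OC)cc2)cc1` — 8.4 uM in a functional assay (aorta) with Rattus norvegicus as the target; a lower number here means that less compound is needed, a higher number that more compound is needed for the effect
compound 2, `COc1ccc(-c2nc(CNC(=O)C3=NNC(=O)CC3)sc2-c2ccc(OC)cc2)cc1` — 7.3 uM in this assay

Compound 1 and compound 2 give numbers that lie within the scatter of each other, so neither stands apart. The unmeasured compound 3 is `COc1ccc(-c2nc(C(=O)N3CCOCC3)sc2-c2ccc(OC)cc2)cc1`. It differs from compound 1 as follows: (morpholin-4-yl)carbonyl in place of (dimethylamino)methyl on an aromatic carbon. Among the compounds with values here, one measured step bears on this change, since the same (dimethylamino)methyl group was exchanged on the same carbon for a larger ring-bearing group: a 1.2-fold lower number from compound 1 to compound 2 (0.06 log units; within the scatter). He therefore expects no step beyond the scatter, a 1.1-fold higher number from compound 1 to compound 3 (0.03 log units; within the scatter). For compound 3 the estimate in this assay is 9 uM, ranging from 3 uM to 27 uM.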

Compound 3, concentration for half-maximal effect: < 100 uM
Compound 3: no number, only a limit; the forecaster's own chance of this, stated with the estimate: 10%; the middle value lies beyond the limit too.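

In this assay, within the data shown here, compound 3 gives only a limit of < 100 uM and not a number, so no step from compound 1 to compound 3 can be read. The compounds shown leave open how compound 3 truly compares with compound 1.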